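Ortho substitution on the pyridine-bearing amide series

A few compounds are considered here, and "the series" means these few. Any claim that something is new, unique, unknown or untested is made for them only; others in the source may bear on it.

Compound 1 `CC(C)(C)c1ccc(NC(=O)c2ccc(-c3ccccn3)cc2)cc1` is the parent of this pair of notes. Within the data shown here, in a functional assay for antagonist activity at transient receptor potential cation channel subfamily V member 1 (Rattus norvegicus) (on this read-out lower numbers stand for stronger inhibition and higher numbers for weaker inhibition), compound 1 gives 8 nM, the lowest of the two numbers measured so far; its nearest neighbour is compound 2 `CC(C)(C)c1ccc(NC(=O)c2ccc(-c3ncccc3C(=O)O)cc2)cc1`, which in this assay gives 560 nM. Among the measured compounds shown here, the single measured step, a 70-fold higher number from compound 1 to compound 2 (1.85 log units; beyond the scatter), is large and runs toward weaker inhibition.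

Compound 3 `CN(C)Cc1cccnc1-c1ccc(C(=O)Nc2ccc(C(C)(C)C)cc2)cc1` has not yet been measured. Its change from compound 1 is (dimethylamino)methyl in place of hydrogen on an aromatic carbon. The new group sits at the same place as the carboxy of compound 2, but it is a different group: no hydrogen-bond donor, one acceptor, no net charge, and four heavy atoms rather than a carboxy.

For the measured compounds named here, only the step from compound 1 to compound 2 bears on this change, and it was large and toward weaker inhibition. A step in the same direction, beyond the scatter, is therefore expected for compound 3, though a smaller one than that seen with carboxy. The expected step is a 15-fold higher number from compound 1 to compound 3 (1.18 log units; beyond the scatter). The estimate for compound 3 in this assay is 120 nM, with a range from 20 nM to 700 nM.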

Compound 3, half-maximal inhibitory concentration: 234 nM
For compound 3 the middle estimate is 2.0-fold (0.29 log units) below the measured one; the measured number falls inside the stated range.
By their numbers in this assay, from the lowest: compound 1; then compound 3; then compound 2.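

In this assay, the rise at this place, on an aromatic carbon ortho to a large group and two atoms from the ring nitrogen, is no longer tied to carboxy alone: (dimethylamino)methyl in place of hydrogen also gives a 29-fold higher number from compound 1 to compound 3 (1.47 log units; beyond the scatter). The two groups are not interchangeable, however, since replacing carboxy with (dimethylamino)methyl gives a 2.4-fold lower number from compound 2 to compound 3 (0.38 log units; beyond the scatter), a modest step beside the large steps from hydrogen, and compound 1 keeps the lowest number of the three. Nothing at hand accounts for either group's effect on the number.

Whether any group at this place can match the hydrogen of compound 1 remains open, as the two groups shown differ from each other in several respects at once and a smaller group such as methyl, hydroxymethyl or a primary aminomethyl would help separate them. Going by these compounds, it is also open whether a longer chain ending in the same dimethylamino group, or a carboxylic acid held further from the ring on a longer chain, would move the number up or down from that of compound 3 or compound 2.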